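Estimating Permeability of Compound 4 from Three Analogues

This account rests on a few compounds, and the source may have more. Where it says the series, first, only, none or still open, it means among the compounds named here.

Of the compounds shown here, three sharing one core have been measured in an ADME assay for permeability, using PAMPA, with a stated time of 30 min, at pH 7.4; on this read-out higher numbers stand for higher permeability and lower numbers for lower permeability. Compound 1 `COc1cccc(CNCCCNc2ccnc3cc(Oc4ccc(F)cc4)ccc23)c1O` gives 317 10^-6 cm/s. Compound 2 `COc1cccc(CNCCCNc2ccnc3cc(CCC(C)C)ccc23)c1O` gives 23 10^-6 cm/s. Compound 3 `COc1cccc(CNCCCNc2ccnc3cc(-c4cccc5ccccc45)ccc23)c1O` gives 237 10^-6 cm/s, the second highest of the three numbers; its nearest neighbour is compound 1, with a 1.3-fold lower number from compound 1 to compound 3 (0.13 log units; within the scatter), while the step of a 10-fold higher number from compound 2 to compound 3 (1.01 log units; beyond the scatter) is large. Compound 4 `COc1cccc(CNCCCNc2ccnc3cc(Oc4ccc(C(C)(C)C)cc4)ccc23)c1O` differs from compound 3 in one place: 4-(tert-butyl)phenoxy in place of naphthalen-1-yl on an aromatic carbon. For the measured compounds named here, two measured steps bear on this change. In the first, naphthalen-1-yl replaced 4-fluorophenoxy, giving a 1.3-fold lower number from compound 1 to compound 3 (0.13 log units; within the scatter), within the scatter. In the second, isopentyl replaced 4-fluorophenoxy, giving the large step of a 14-fold lower number from compound 1 to compound 2 (1.14 log units; beyond the scatter). The group entering compound 4, 4-(tert-butyl)phenoxy, resembles the 4-fluorophenoxy of compound 1, and compound 1 and compound 3 differ only within the scatter. Compound 4 is therefore expected to show a step of a 1.2-fold higher number from compound 3 to compound 4 (0.07 log units; within the scatter) that stays within the scatter. The estimate for compound 4 in this assay is 280 10^-6 cm/s, with a range from 140 10^-6 cm/s to 560 10^-6 cm/s.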

Compound 4, apparent permeability: 317 10^-6 cm/s
Estimate against measurement, compound 4: 1.1-fold (0.05 log units) below; the range from low to high includes it.
By their numbers in this assay, from the lowest: compound 2; then compounds 3, 1 and 4 (each within the scatter of the next).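

In this assay, the phenoxy group tolerates a much larger substituent than fluoro: tert-butyl in its place gives no change at the digits printed from compound 1 to compound 4 (within the scatter), so the two phenoxy groups cannot be told apart here. The exchange of the two aromatic rings of naphthalen-1-yl for the single ring and oxygen of 4-(tert-butyl)phenoxy gives a 1.3-fold higher number from compound 3 to compound 4 (0.13 log units; within the scatter), whereas replacing isopentyl with the same group gives a 14-fold higher number from compound 2 to compound 4 (1.14 log units; beyond the scatter), which leaves compound 2, the only one of the four without an aromatic ring in this group, apart from the other three. Nothing shown gives a cause for this pattern.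

Whether the low number of compound 2 belongs to isopentyl alone or extends to other open chains remains unsettled. Going by these compounds, how an amine, a carboxylic acid or a longer chain on this aromatic carbon would read also remains open.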